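Chloro in Place of Ethyl: An Expected Outcome

A few compounds are considered here, and "the series" means these few. Any claim that something is new, unique, unknown or untested is made for them only; others in the source may bear on it.

Two compounds have so far been measured in a functional assay on A549 cells (Homo sapiens) for antiproliferative activity, read by MTT assay, with a stated time of 48 h; a higher number here means a weaker inhibitor, a lower number a stronger inhibitor:

Compound 1, `N#CC1=C(N)Oc2c(c3nc4ccccc4nc3c3ccccc23)C12C(=O)N(Cc1cnnn1-c1cccc(S(N)(=O)=O)c1)c1ccccc12`, gives 44200 nM in this assay.
Compound 2, `CCc1ccccc1-n1nncc1CN1C(=O)C2(C(C#N)=C(N)Oc3c(N)cc4nc5ccccc5nc4c32)c2ccccc21`, gives 24600 nM in this assay.

Compound 2 holds the lowest of the two numbers, but its nearest neighbour, compound 1, sits within the scatter of it, so the two cannot be ordered. Compound 3, `N#CC1=C(N)Oc2c(N)cc3nc4ccccc4nc3c2C12C(=O)N(Cc1cnnn1-c1ccccc1Cl)c1ccccc12`, differs from compound 2 by chloro in place of ethyl on an aromatic carbon. Within the data shown here, no measured pair shows this exchange, so nothing in the present data tells which way it moves the number. Both measured compounds lie in the same region of this assay, and compound 3 keeps the rest of the structure of compound 2 unchanged. The step from compound 2 to compound 3 is therefore expected to be a 1.1-fold higher number from compound 2 to compound 3 (0.02 log units; within the scatter), that is, none beyond the scatter. Compound 3 is estimated at 26000 nM, with a range from 10000 nM to 65000 nM.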

Compound 3, half-maximal inhibitory concentration: 29800 nM
Compound 3: middle estimate off by 1.1-fold (0.06 log units), on the low side; measured number inside the range.
By their numbers in this assay, from the lowest: compounds 2, 3 and 1 (each within the scatter of the next).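

In this assay, among these compounds, compounds 2 and 3 form the first pair that differs in one place, and going from 2-ethylphenyl to 2-chlorophenyl gives a 1.2-fold higher number from compound 2 to compound 3 (0.08 log units; within the scatter). On this aromatic carbon, ortho to a large group, the exchange of ethyl for chloro therefore does not separate the two compounds, so this change can be set down as one without a readable effect on the number. No measurement is available here that would account for this result.

From the compounds shown here alone, whether this position can move the number at all remains open, since only ethyl and chloro stand there, and an amine, a methoxy group or a carboxylic acid in the same place could show otherwise. The compounds shown also contain no step beyond the scatter, at this place or any other.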